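This account rests on a few compounds, and the source may have more. Where it says the series, first, only, none or still open, it means among the compounds named here.

Among the measured compounds shown here, in an ADME assay on MT4 cells (Homo sapiens) for cytotoxicity, read by MTT assay, with a stated time of 4 days (on this read-out higher numbers stand for lower toxicity in this test and lower numbers for higher toxicity in this test), three compounds built on a shared core have numbers so far. Compound 1 `Cc1ccc(-c2c(C)c(-c3ccc(C)c(C)c3)c(C(OC(C)(C)C)C(=O)O)c(C)c2NS(C)(=O)=O)cc1C` gives 15000 nM, compound 2 `CC(=O)Nc1c(C)c(C(OC(C)(C)C)C(=O)O)c(-c2ccc(C)c(C)c2)c(C)c1-c1ccc(C)c(C)c1` gives 19000 nM, and compound 3 `CCC(=O)Nc1c(C)c(C(OC(C)(C)C)C(=O)O)c(-c2ccc(C)c(C)c2)c(C)c1-c1ccc(C)c(C)c1` gives 15000 nM. Compound 3 therefore stands level with compound 1, and compound 2 lies within the usual scatter of both.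

Compound 4 `Cc1ccc(-c2c(C)c(-c3ccc(C)c(C)c3)c(C(OC(C)(C)C)C(=O)O)c(C)c2NS(=O)(=O)C2CC2)cc1C` differs from compound 3 in one place, with cyclopropylsulfonyl in place of propanoyl on a nitrogen on an aromatic ring. For the measured compounds named here, three measured steps bear on this change. Replacing methylsulfonyl on that nitrogen gave a 1.3-fold higher number from compound 1 to compound 2 (0.10 log units; within the scatter) and no change at the digits printed from compound 1 to compound 3 (within the scatter), while adding a methyl to the acetyl chain gave a 1.3-fold lower number from compound 2 to compound 3 (0.10 log units; within the scatter). Going by the values given here, all three lie within the scatter, although no measured compound carries a cyclopropyl group there. No step beyond the scatter is therefore expected in this assay. The expected step is no change at the digits printed from compound 3 to compound 4 (within the scatter). For compound 4 the estimated value is 15000 nM, expected to fall between 8000 nM and 27000 nM.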

Compound 4, half-maximal cytotoxic concentration: 11000 nM
Beside the measured number, compound 4's estimate is 1.4-fold (0.13 log units) above it; low and high end bracket the measured number.
By their numbers in this assay, from the lowest: compounds 4, 1, 3 and 2 (each within the scatter of the next).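

In this assay the change of propanoyl to cyclopropylsulfonyl gives a 1.4-fold lower number from compound 3 to compound 4 (0.13 log units; within the scatter) and the change of acetyl to cyclopropylsulfonyl gives a 1.7-fold lower number from compound 2 to compound 4 (0.24 log units; within the scatter) while cyclopropyl in place of methyl on the sulfonyl sulfur gives a 1.4-fold lower number from compound 1 to compound 4 (0.13 log units; within the scatter) in this series. A three-membered ring of carbon on the sulfonyl group therefore keeps compound 4 within the scatter of all three earlier compounds, so this nitrogen on an aromatic ring has now carried two amides and two sulfonamides with no separation among them. No measured information here accounts for the small differences that remain.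

Still open, as far as these compounds go, is whether a larger group on the sulfonyl sulfur, such as a phenyl ring or a longer chain, would give a number beyond the scatter. From the compounds shown here alone, a free amine on the aromatic ring is equally open.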